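A few compounds are considered here, and "the series" means these few. Any claim that something is new, unique, unknown or untested is made for them only; others in the source may bear on it.

Measured so far:
compound 1, `CCN(CC)C(=O)CC1CCc2cc(OC)c(OC)cc21`, 31.5%
compound 2, `CCCCCCNC(=O)CC1CCc2cc(OC)c(OC)cc21`, 38.3%

Among the measured compounds shown here, in a functional assay on the whole organism (strain Wistar) for inhibition, with Rattus norvegicus as the target, read by paw edema, with stated times of 60 min and 6 h, at a dose of 100 mg/kg by the oral route (on this read-out lower numbers stand for less inhibition and higher numbers for more inhibition at the one dose given (going by the name of the read-out)), compound 2 stands highest of the two numbers, though the one step to it, a number 6.8 percentage points higher from compound 1 to compound 2 (within the scatter), sits within the scatter, so the two tertiary and secondary amides cannot be told apart on this read-out. Compound 3, `COc1cc2c(cc1OC)C(CC(=O)N1CCCCC1)CC2`, differs from compound 2 by piperidin-1-yl in place of hexylamino on a carbonyl carbon. For the measured compounds named here, the only measured step changes the same amide substituent and gave no shift beyond the scatter, so for compound 3 a step of a number 4.3 percentage points lower from compound 2 to compound 3 (within the scatter) near nothing is expected. Compound 3 is therefore estimated at 34%, within 20% to 48%.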

Compound 3, a percentage reported as inhibition, in the whole organism at one dose (the size of the read-out at that dose, not a potency): 31.5%
Beside the measured number, compound 3's estimate is 2.5 percentage points above it; low and high end bracket the measured number.
By their numbers in this assay, from the lowest: compounds 1, 3 and 2 (each within the scatter of the next).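

Piperidin-1-yl on a carbonyl carbon, a ring that carries no amide hydrogen, gives a number 6.8 percentage points lower from compound 2 to compound 3 (within the scatter) in this assay and also no change at the digits printed from compound 1 to compound 3 (within the scatter). Ring, open hexylamino chain and diethylamino therefore cannot be told apart on this read-out, with or without the amide hydrogen. No measurement here offers an explanation for this.

Still open, going by these compounds, is whether morpholin-4-yl, a chain ending in a carboxylic acid or an amine, or a chain longer than hexylamino at this place would move the number beyond the scatter.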